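Methylimidazole in Place of the Triazole Ring

A few compounds are considered here, and "the series" means these few. Any claim that something is new, unique, unknown or untested is made for them only; others in the source may bear on it.

Three compounds have been measured in an in vitro functional assay on cells (Fibroblast) for agonist activity at Alpha-1A adrenergic receptor (Homo sapiens); on this read-out lower numbers stand for an effect already at smaller amounts and higher numbers for an effect only at larger amounts of compound:

Compound 1 `Cc1n[nH]c(-c2ccccc2NCC2=NCCN2)n1`: 794 nM
Compound 2 `Cc1nc(-c2ccccc2NCC2=NCCN2)n(C)n1`: 1000 nM
Compound 3 `CCn1cc(-c2ccccc2NCC2=NCCN2)cn1`: < 100000 nM, which is a limit of the assay, not a number

Within the data shown here, compound 1 carries the lowest of the two numbers, and its only neighbour, compound 2, sits within the scatter of it: a 1.3-fold higher number from compound 1 to compound 2 (0.10 log units; within the scatter), a methyl on the ring nitrogen replacing its hydrogen. Compound 3 gives only the limit of < 100000 nM in this assay, at which 1 of the 3 values shown sits, and so offers no number to compare.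

Compound 4 `Cn1ccnc1-c1ccccc1NCC1=NCCN1` differs from compound 1 by 1-methyl-1H-imidazol-2-yl in place of 3-methyl-1H-1,2,4-triazol-5-yl on an aromatic carbon. Among the measured compounds shown here, the one measured step that bears on it, from compound 1 to compound 2, also took away the hydrogen on the ring nitrogen and stayed within the scatter. For the measured compounds named here, the exchange of the ring itself has no measured counterpart, so a step in this assay of modest size, if any, is expected, most likely towards a somewhat higher number. Compound 4 is therefore estimated at 1500 nM, within 300 nM to 8000 nM, which means an expected step of a 1.9-fold higher number from compound 1 to compound 4 (0.28 log units; within the scatter).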

Compound 4, half-maximal effective concentration: 6.31 nM
For compound 4 the middle estimate is 240-fold (2.38 log units) above the measured one, and the stated range ends above it.
By their numbers in this assay, from the lowest: compound 4; then compounds 1 and 2 (each within the scatter of the next).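

In this assay, the exchange of the five-membered ring on this aromatic carbon gives a 130-fold lower number from compound 1 to compound 4 (2.10 log units; beyond the scatter), whereas the methyl on the ring nitrogen gave only a 1.3-fold higher number from compound 1 to compound 2 (0.10 log units; within the scatter). Compound 2 also lacks the ring hydrogen of compound 1 and stays within the scatter of it, so the removal of that hydrogen alone does not go with a large step, and the identity of the ring itself emerges as what matters at this place. Compound 3 gives no number for comparison, only a limit of the assay: the limit of < 100000 nM in this assay, at which 1 of the 4 values shown sits.

The compounds shown do not separate the effect of the ring carbon that replaces a ring nitrogen from that of the relocated methyl, and they offer no measurement that explains the step. They also leave open whether the low number of compound 4 would survive propyl in place of the methyl on the imidazole, or an amine on that ring.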